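A few compounds are considered here, and "the series" means these few. Any claim that something is new, unique, unknown or untested is made for them only; others in the source may bear on it.

Compound 1 `C#CCOc1ccccc1-c1cc(-c2ccccc2OCC#C)nc(N)n1` was examined in an assay on BTI-TN-5B1-4 cells for inhibition of Amine oxidase [flavin-containing] A (Homo sapiens), read by fluorescence and Amplex Red, using microsomes, with a stated time of 30 min (a higher number here means a weaker inhibitor, a lower number a stronger inhibitor), where compound 1 gives "not active" (no number reported). Compound 2 `C#CCOc1ccc(-c2cc(-c3ccc(OCC#C)c(OCC)c3)nc(-c3ccccc3)n2)cc1` in this assay likewise gives "not active" (no number reported). Compound 3 `C#CCOc1ccc(-c2cc(-c3cccc(OCC#C)c3)nc(N)n2)cc1`, carrying the amino group and the propargyloxy groups in another arrangement, in this assay gives 24100 nM, the only numerical result among the three measured compounds. Compound 4 `C#CCOc1ccccc1-c1cc(-c2ccccc2OCC#C)nc(-c2ccccc2)n1` has not yet been measured. It differs from compound 1 by phenyl in place of amino on an aromatic carbon. For the measured compounds named here, no step between measured compounds is available for this change, so its size can only be guessed: compound 2, which carries the same phenyl group in the same position, and compound 1, which carries the amino group, both failed to show activity, which suggests no step beyond the scatter toward stronger inhibition. The account therefore expects compound 4 to remain a weak or inactive inhibitor, estimated at 60000 nM within a range from 15000 nM to 250000 nM.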

Compound 4, half-maximal inhibitory concentration: "not active" (no number reported)
The entry for compound 4 holds no number, and the estimate cannot be compared.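

In this assay compound 1 gives "not active" (no number reported) and compound 4 gives "not active" (no number reported) so no step can be read for phenyl in place of amino. The compounds shown leave open how large this change would be on a compound with a numerical value. Nothing shown offers an explanation for the result.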